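A few compounds are considered here, and "the series" means these few. Any claim that something is new, unique, unknown or untested is made for them only; others in the source may bear on it.

Measured so far in a functional assay on SF-539 cells (Homo sapiens) for inhibition, read by sulforhodamine B assay, with a stated time of 48 h; on this read-out lower numbers stand for stronger inhibition of growth and higher numbers for weaker inhibition of growth:
Compound 2 `N#C/C(=C\N1CCN(C(=O)c2ccco2)C1=S)C(=O)c1ccccc1` gives 2200 nM.
Compound 3 `O=CN1CCN(c2ccc(Cl)cc2)C1=S` gives 26600 nM.
Compound 1 `N#C/C(=C\N1CCN(C(=O)c2ccco2)C1=S)C(=O)Nc1ccc(Cl)cc1` gives "not determined" (no result reported).

Compound 3 stands at the higher of the two numbers, meaning weaker growth inhibition; the gap to compound 2 lies well beyond the usual scatter. Compound 4 `O=CN1CCN(c2ccc(Cl)c(Cl)c2)C1=S` differs from compound 3 by chloro in place of hydrogen on an aromatic carbon. For the measured compounds named here, no measured pair shows this change on its own, so its size is unknown here. In this assay a small step is expected, leaning towards a lower number, though not clearly beyond the scatter. Compound 4 is therefore expected to give about 18000 nM, within a range from 6000 nM to 50000 nM. That estimate amounts to an expected step of a 1.5-fold lower number from compound 3 to compound 4 (0.17 log units; within the scatter).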

Compound 4, concentration for 50% growth inhibition: 20600 nM
Estimate against measurement, compound 4: 1.1-fold (0.06 log units) below, within the range that was stated.
By their numbers in this assay, from the lowest: compound 2; then compounds 4 and 3 (each within the scatter of the next).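

In this assay, for the compounds shown here, chloro in place of hydrogen on the aromatic carbon ortho to a chloro group and meta to a group of 8 heavy atoms gives a 1.3-fold lower number from compound 3 to compound 4 (0.11 log units; within the scatter) and so offers the first comparison here of compounds that differ in one place. At this position, the second chloro brings no clear gain or loss of growth inhibition. No measured property is at hand to explain this result. From the compounds shown here alone, whether an amine or a methoxy group at this same position would shift the number remains open.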